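Swapping an acetyl for a nitro-bearing benzoyl group

The source may hold more compounds than are shown below. What is called first, only, known or untested is meant among the compounds shown, and "the series" means these compounds.

Compound 1 `CC(=O)Nc1c(C(O)(C(F)(F)F)C(F)(F)F)ccc2ccccc12` carries a small acetyl group on its amide nitrogen. In a functional assay (Sus scrofa) with sulfonylurea receptors; K-ATP channels (Homo sapiens) as the target (a higher number here means a larger maximal response, a lower number a smaller maximal response), compound 1 gives 87%. Two close relatives replace that acetyl with a benzoyl group bearing a substituent: compound 2 `Cc1cccc(C(=O)Nc2c(C(O)(C(F)(F)F)C(F)(F)F)ccc3ccccc23)c1` gives 97% in this assay, and compound 3 `N#Cc1cccc(C(=O)Nc2c(C(O)(C(F)(F)F)C(F)(F)F)ccc3ccccc23)c1` gives 96%. Going by the values given here, of the three numbers measured, the one for compound 1 is the lowest, but its distance to each of the others is small: a number 10 percentage points higher from compound 1 to compound 2 (within the scatter) and a number 9 percentage points higher from compound 1 to compound 3 (within the scatter) both fall inside the usual scatter, and so does a number 1 percentage points lower from compound 2 to compound 3 (within the scatter). Among the compounds with values here, no compound can therefore be called stronger or weaker than another on these data.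

Compound 4 `O=C(Nc1c(C(O)(C(F)(F)F)C(F)(F)F)ccc2ccccc12)c1cccc([N+](=O)[O-])c1` follows the same pattern of change from compound 1: 3-nitrophenyl in place of methyl on a carbonyl carbon. The two measured steps of the same kind, from compound 1 to compound 2 and from compound 1 to compound 3, were both small, and exchanging one substituent on the benzoyl ring for another, from compound 2 to compound 3, changed nothing beyond the scatter. The expected step is therefore a number 8 percentage points higher from compound 1 to compound 4 (within the scatter), a small rise that stays within the scatter. Compound 4 is estimated to give 95% in this assay, with a likely range from 85% to 104%.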

Compound 4, largest response reached (reported as efficacy), in percent of the reference or control that the assay uses: 99%
For compound 4 the middle estimate is 4 percentage points below the measured one; low and high end bracket the measured number.
By their numbers in this assay, from the lowest: compounds 1, 3, 2 and 4 (each within the scatter of the next, the first and the last beyond it).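

Going by these compounds alone, the new result gives the first step at this position that lies beyond the usual scatter (a number 12 percentage points higher from compound 1 to compound 4 (beyond the scatter)), so in this assay a 3-nitrophenyl group on this carbonyl carbon can be told apart from methyl, though only modestly. This does not single out nitro among the ring substituents, since nitro in place of cyano (a number 3 percentage points higher from compound 3 to compound 4 (within the scatter)) and nitro in place of methyl (a number 2 percentage points higher from compound 2 to compound 4 (within the scatter)) both stay inside the scatter, and these three substituted phenyl groups therefore cannot be separated from one another. Nothing in the available data explains the step from the methyl group to the 3-nitrophenyl group.

The compounds shown leave open how a plain phenyl group with no substituent, a phenyl ring carrying an amine or a carboxylic acid, or a longer alkyl chain such as propyl would behave on this carbonyl carbon. They also leave open whether a nitro group placed elsewhere on the phenyl ring would give a similar response, which would help show how much the position of the substituent matters.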